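Replacing the Benzyl Ether of Compound 2 with a Propyl Ether

This account rests on a few compounds, and the source may have more. Where it says the series, first, only, none or still open, it means among the compounds named here.

Of the compounds shown here, two that share one core have been measured in a functional assay on J774.A1 cells (Mus musculus) for inhibition, read by Griess assay, with stated times of 1 h and 24 h; on this read-out lower numbers stand for stronger inhibition and higher numbers for weaker inhibition. Compound 1 `O=C1CC(c2ccccc2OCc2ccccc2)Oc2ccccc21` gives 23200 nM. Within the data shown here, compound 2 `CC(C)c1ccc(COc2ccccc2C2CC(=O)c3ccccc3O2)cc1` gives 28600 nM, and the only measured step, a 1.2-fold higher number from compound 1 to compound 2 (0.09 log units; within the scatter), leaves the two side by side; compound 2 thus stands together with its single neighbour, with no real gap between them.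

Compound 3 `CCCOc1ccccc1C1CC(=O)c2ccccc2O1` has not yet been measured. It differs from compound 2 by ethyl in place of 4-isopropylphenyl on a saturated chain carbon bound to an oxygen on an aromatic ring. Among the measured compounds shown here, the one measured step bears on this change only loosely: a 1.2-fold higher number from compound 1 to compound 2 (0.09 log units; within the scatter) altered the same side chain yet left the number essentially unchanged, whereas here the whole six-membered aromatic ring of carbon only departs and an ethyl takes its place. For the measured compounds named here, no measured pair shows what removing that ring does. For compound 3 the expected step is a 1.2-fold higher number from compound 2 to compound 3 (0.09 log units; within the scatter), a small shift toward weaker inhibition that may well stay within the scatter, since the side chain so far has mattered little. Compound 3 is therefore estimated at 35000 nM in this assay, with a range from 12000 nM to 100000 nM.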

Compound 3, half-maximal inhibitory concentration: 44600 nM
Beside the measured number, compound 3's estimate is 1.3-fold (0.11 log units) below it; the range from low to high includes it.
By their numbers in this assay, from the lowest: compounds 1, 2 and 3 (each within the scatter of the next).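

Replacing the whole 4-isopropylphenyl with ethyl in this assay gives a small step (a 1.6-fold higher number from compound 2 to compound 3 (0.19 log units; within the scatter)), and replacing phenyl with ethyl gives a similar result (a 1.9-fold higher number from compound 1 to compound 3 (0.28 log units; within the scatter)). The earlier pair showed only that a group added to the aromatic ring of this side chain left the number within the scatter, whereas these steps show that the six-membered aromatic ring of carbon only can itself go from this place, on a saturated chain carbon bound to an oxygen on an aromatic ring, without a change beyond the scatter, so the compounds shown give no sign that this ring is needed for the inhibition read here. No measurement at hand offers an explanation for how close these numbers stay.

On these data alone, all the groups compared at this place are made of carbon alone, so it remains open whether an amine, a carboxylic acid or a hydroxyl at the end of the chain would move the number beyond the scatter. As far as these compounds go, it is also open whether a much longer chain, or a change to the shared core rather than to this side chain, would do so.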